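This account rests on a few compounds, and the source may have more. Where it says the series, first, only, none or still open, it means among the compounds named here.

Compound 1, `COc1ccc(/C=C/C(=O)OC[C@@H](OCc2ccccc2)[C@H]2OC(=O)C=C[C@H]2OCc2ccccc2)cc1`: 1080 nM
Compound 2, `O=C1C=C[C@@H](OCc2ccccc2)[C@@H]([C@@H](COC(=O)/C=C/c2ccc(F)cc2)OCc2ccccc2)O1`: 7310 nM
Compound 3, `CC(=O)OC[C@@H](OCc1ccccc1)[C@H]1OC(=O)C=C[C@H]1OCc1ccccc1`: 5350 nM

In a functional assay on HeLa cells (Homo sapiens) for antiproliferative activity, read by MTT assay, with a stated time of 6 days (a lower number here means a stronger inhibitor, a higher number a weaker inhibitor), compound 3 has the second highest of the three numbers. The step of a 5.0-fold higher number from compound 1 to compound 3 (0.69 log units; beyond the scatter) lies beyond the usual scatter, whereas a 1.4-fold lower number from compound 2 to compound 3 (0.14 log units; within the scatter) lies within it. Compound 4, `O=C1C=C[C@@H](OCc2ccccc2)[C@@H]([C@@H](CO)OCc2ccccc2)O1`, differs from compound 3 by hydrogen in place of acetyl on an oxygen on a saturated carbon. Both measured steps alter the group on the same carbonyl carbon that compound 4 loses entirely, so they bear on this change only loosely: they show that exchanging that group shifts this assay by modest amounts, and never below the number of compound 1. Removing the acetyl is therefore expected to give a modest change, most likely toward a higher number, a 1.7-fold higher number from compound 3 to compound 4 (0.23 log units; within the scatter). Compound 4 is estimated at 9000 nM, with a range of 3000 nM to 30000 nM.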

Compound 4, half-maximal inhibitory concentration: 4800 nM
The estimate for compound 4 lay 1.9-fold (0.27 log units) above the measured number; low and high end bracket the measured number.
By their numbers in this assay, from the lowest: compound 1; then compounds 4, 3 and 2 (each within the scatter of the next).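

The free hydroxy group of compound 4 sits level in this assay with both the acetyl ester of compound 3 (a 1.1-fold lower number from compound 3 to compound 4 (0.05 log units; within the scatter)) and the (2-(4-fluorophenyl)ethenyl)carbonyl ester of compound 2 (a 1.5-fold lower number from compound 2 to compound 4 (0.18 log units; within the scatter)). Only the (2-(4-methoxyphenyl)ethenyl)carbonyl ester of compound 1 stands apart from hydrogen on this oxygen (a 4.4-fold higher number from compound 1 to compound 4 (0.65 log units; beyond the scatter)), so having an ester here is not enough on its own to separate a compound from the free hydroxy. Nothing available explains why this one ester differs.

Still open, on these data alone, is how a methyl ether or an amine at this position would compare. It is also unclear whether a plain benzoyl ester would match compound 1 or the others.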